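Trading a Cyclobutyl Amide for a Methoxyethyl Amide

The source may hold more compounds than are shown below. What is called first, only, known or untested is meant among the compounds shown, and "the series" means these compounds.

Measured compounds:
compound 1 `CNC(=O)c1cc(C(=O)NC2CCC2)cn(Cc2ccccn2)c1=O`: 2.2
compound 2 `CNC(=O)c1cc(C(=O)NC2CCC2)cn(Cc2ccccc2)c1=O`: 3.8
compound 3 `CNC(=O)c1cc(C(=O)NC2CCC2)cn(Cc2cccnc2)c1=O`: 1.8

In a physicochemical assay for lipophilicity, at pH 7.4 (on this read-out lower numbers stand for lower lipophilicity and higher numbers for higher lipophilicity), compound 2 gives 3.8, the highest of the three measured values, with compound 1 nearest and compound 3 furthest away. The three measured steps, a number 1.60 log units higher from compound 1 to compound 2 (beyond the scatter), a number 2.00 log units lower from compound 2 to compound 3 (beyond the scatter) and a number 0.40 log units lower from compound 1 to compound 3 (beyond the scatter), all concern the group on a saturated chain carbon bound to an aromatic nitrogen; each leaves the cyclobutylcarbamoyl side untouched.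

Compound 4 `CNC(=O)c1cc(C(=O)NCCOC)cn(Cc2ccccc2)c1=O` differs from compound 2 at a different place: 2-methoxyethyl in place of cyclobutyl on an amide-type nitrogen. Within the data shown here, none of the measured steps bears on this change, so the expectation rests on the structures alone, where a ring of carbon only gives way to an open chain that carries a hydrogen-bond acceptor. A modest drop in this assay is therefore expected, a number 0.90 log units lower from compound 2 to compound 4 (beyond the scatter). Compound 4 is estimated at 2.9, with a range from 2.4 to 3.4.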

Compound 4, distribution coefficient: 2.7
Estimate against measurement, compound 4: 0.20 log units above; low and high end bracket the measured number.
By their numbers in this assay, from the lowest: compound 3; then compound 1; then compound 4; then compound 2.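

Until now, every measured step lay in the group on the saturated chain carbon; this one shows that the amide-type nitrogen is a second place where this assay responds, with a number 1.10 log units lower from compound 2 to compound 4 (beyond the scatter). Cyclobutyl and 2-methoxyethyl have the same heavy-atom count, so this step comes with no growth in the group, only a carbon ring replaced by an open chain carrying a hydrogen-bond acceptor. Nothing shown separates the part played by the oxygen from the part played by opening the ring.

From the compounds shown here alone, it remains open whether the same swap gives a step of similar size when pyridin-2-yl or pyridin-3-yl replaces phenyl, as in compound 1 and compound 3. Also open, going by these compounds, is how an all-carbon butyl chain, or a chain ending in an amine, would read on this amide-type nitrogen.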